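Working notes: liver microsome half-lives across three analogues

The source may hold more compounds than are shown below. What is called first, only, known or untested is meant among the compounds shown, and "the series" means these compounds.

Two compounds have numbers in an ADME assay on microsomes from liver (Rattus norvegicus) for metabolic stability; on this read-out higher numbers stand for a longer-lived compound and lower numbers for a shorter-lived compound. Compound 1 `CCC(CC)(c1nnc[nH]1)c1ccc(-c2ccc3cc(F)cc(F)c3c2)[nH]c1=O` gives 1.26 h. Compound 2 `Cc1nc(C(c2ccc(-c3ccc4cccc(F)c4c3)[nH]c2=O)C(C)C)[nH]c1C` gives 0.0733 h, the lowest of the two, with compound 1 standing higher by a margin beyond the scatter. Compound 3 `CC(C)C(CC(N)=O)c1ccc(-c2ccc3cccc(F)c3c2)[nH]c1=O` has not yet been measured. Compound 3 differs from compound 2 by carbamoylmethyl in place of 4,5-dimethyl-1H-imidazol-2-yl on a saturated chain carbon bound to an aromatic carbon and a saturated chain carbon. Among the compounds with values here, no step between measured compounds covers this change. Compound 2 stands low at 0.0733 h in this assay. From compound 2 a moderate rise beyond the scatter is expected, a 3.4-fold higher number from compound 2 to compound 3 (0.53 log units; beyond the scatter). For compound 3 the estimate in this assay is 0.25 h, in the range 0.08 h to 0.8 h.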

Compound 3, half-life: < 0.0667 h
Compound 3: no number, only a limit (the forecaster's own chance of this, stated with the estimate: 5%); middle value at least 3.7-fold (0.57 log units) away from the limit.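

At this saturated chain carbon, carbamoylmethyl in place of 4,5-dimethyl-1H-imidazol-2-yl gives an at least 1.0-fold lower number from compound 2 to compound 3 (0.04 log units; that floor lies within the scatter). Giving up the five-membered ring here therefore brings no detectable gain in half-life in this assay, which compound 2 alone could not show. Compound 3 has a limit rather than a number: the limit of < 0.0667 h in this assay, at which 1 of the 3 values shown sits.

How far compound 3 truly lies from compound 2 remains unresolved, as the limit leaves their order within the scatter. As far as these compounds go, whether a carboxylic acid or an amine at this carbon would lengthen the half-life in this assay also stays open.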